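Pyrrolidine for Diethylamine on the Trifluoromethyl Analogue

The source may hold more compounds than are shown below. What is called first, only, known or untested is meant among the compounds shown, and "the series" means these compounds.

Compound 3 `CCN(CC)CCCNc1ccnc2cc(C(F)(F)F)ccc12` is one of three close analogues examined in a functional assay on MCF7 cells (Homo sapiens) for antiproliferative activity, read by sulforhodamine B assay, with a stated time of 48 h; on this read-out higher numbers stand for weaker inhibition of growth and lower numbers for stronger inhibition of growth. In this assay compound 3 gives 20600 nM, which places it second highest of the three numbers, although all three sit within the scatter of one another: compound 1 `CCN(CC)CCCNc1ccnc2cc(Cl)ccc12` gives 17900 nM and compound 2 `Clc1ccc2c(NCCCN3CCCC3)ccnc2c1` gives 21500 nM. Compound 4 `FC(F)(F)c1ccc2c(NCCCN3CCCC3)ccnc2c1` has not yet been measured. It differs from compound 3 by a single change, (pyrrolidin-1-yl in place of diethylamino on a saturated chain carbon, three bonds along the chain from a nitrogen on an aromatic ring). For the measured compounds named here, two measured steps bear on this. One is the swap of the ring substituent on the shared core, a 1.2-fold higher number from compound 1 to compound 3 (0.06 log units; within the scatter), which stays within the scatter. The other is the identical amine exchange carried out on the chloro analogue, a 1.2-fold higher number from compound 1 to compound 2 (0.08 log units; within the scatter), again within the scatter. If the amine exchange behaves on the trifluoromethyl-bearing core as it did on the chloro-bearing core, no step beyond the scatter is expected in this assay. Compound 4 is therefore expected to give about 24000 nM, with a likely range from 12000 nM to 50000 nM. This corresponds to an expected step of a 1.2-fold higher number from compound 3 to compound 4 (0.07 log units; within the scatter), essentially flat.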

Compound 4, concentration for 50% growth inhibition: 36800 nM
Estimate against measurement, compound 4: 1.5-fold (0.19 log units) below; measured number inside the range.
By their numbers in this assay, from the lowest: compounds 1, 3, 2 and 4 (each within the scatter of the next, the first and the last beyond it).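

In this assay, the exchange of diethylamino for pyrrolidin-1-yl on the trifluoromethyl-bearing core gives a 1.8-fold higher number from compound 3 to compound 4 (0.25 log units; within the scatter), and the exchange of chloro for trifluoromethyl on the core carrying pyrrolidin-1-yl gives a 1.7-fold higher number from compound 2 to compound 4 (0.23 log units; within the scatter). Each change can now be read on two cores, and the amine exchange at this saturated chain carbon gives two readings that cannot be told apart: the same change on two cores in this assay, a 1.2-fold higher number (0.08 log units; within the scatter) from compound 1 to compound 2 and a 1.8-fold higher number (0.25 log units; within the scatter) from compound 3 to compound 4, 1.5-fold (0.17 log units) apart, within the scatter of two such steps. The ring substituent change likewise gives two readings that agree as far as the scatter allows: the same change on two cores in this assay, a 1.2-fold higher number (0.06 log units; within the scatter) from compound 1 to compound 3 and a 1.7-fold higher number (0.23 log units; within the scatter) from compound 2 to compound 4, 1.5-fold (0.17 log units) apart, within the scatter of two such steps.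

Since every step between compounds differing in one place stays within the scatter, the four compounds cannot show whether the amine exchange truly depends on the ring substituent. From the compounds shown here alone, it also remains open whether a piperidin-1-yl or morpholin-4-yl group in the place of diethylamino, a longer chain, or a nitrile in the place of trifluoromethyl would give a step beyond the scatter in this assay.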